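Swapping a group on the shared core: an expected outcome

A few compounds are considered here, and "the series" means these few. Any claim that something is new, unique, unknown or untested is made for them only; others in the source may bear on it.

Compound 1 (`CC(C)(C)n1cc2c(n1)C(=O)CC1(CCN(C(=O)c3cc(-c4ccccn4)nc4ccccc34)CC1)O2`): 8100 nM
Compound 2 (`CN1CCN(c2cc(C(=O)N3CCC4(CC3)CC(=O)c3nn(C(C)(C)C)cc3O4)c3ccccc3n2)CC1`): 8130 nM

Both values come from a functional assay on MDA-MB-231 cells (Homo sapiens) for inhibition, read by MTT assay, with a stated time of 72 h; on this read-out higher numbers stand for weaker inhibition and lower numbers for stronger inhibition. Compound 2 has only compound 1 to stand against, and the two values lie within the scatter of each other. Compound 3 (`CCOc1cc(C(=O)N2CCC3(CC2)CC(=O)c2nn(C(C)(C)C)cc2O3)c2ccccc2n1`) has not yet been measured. It differs from compound 2 as follows: ethoxy in place of 4-methylpiperazin-1-yl on an aromatic carbon. In words, this is ethoxy in place of 4-methylpiperazin-1-yl on an aromatic carbon, next to the ring nitrogen.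

For the measured compounds named here, one measured step bears on this change, since it concerns the same aromatic carbon, with 4-methylpiperazin-1-yl in place of pyridin-2-yl: a 1.0-fold higher number from compound 1 to compound 2 (0.00 log units; within the scatter). Going by the values given here, that step stayed within the scatter, but it is a single step, and no compound carrying ethoxy has been measured. In this assay, no shift beyond the scatter is therefore expected, in either direction, and the expected step is a 1.1-fold lower number from compound 2 to compound 3 (0.04 log units; within the scatter). For compound 3 the estimated value is 7500 nM, with an expected range from 3000 nM to 18000 nM.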

Compound 3, half-maximal inhibitory concentration: > 10000 nM
Compound 3 ended at the assay's limit; the forecaster's own chance of this, stated with the estimate: 10%; at least 1.3-fold (0.12 log units) between middle value and limit.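

In this assay compound 3, with ethoxy on this aromatic carbon next to the ring nitrogen, gives > 10000 nM, and this is a limit of the assay, not a number: the limit of > 10000 nM in this assay, at which 1 of the 3 values shown sits.

Set against the two ring-bearing groups, ethoxy gives an at least 1.2-fold higher number from compound 2 to compound 3 (0.08 log units; that floor lies within the scatter) and an at least 1.2-fold higher number from compound 1 to compound 3 (0.09 log units; that floor lies within the scatter); each of these is only a floor, and since both floors lie within the scatter, neither establishes a real loss, while the true size of each step stays unknown. For the compounds shown here, what this adds is that the position is no longer seen only through pyridin-2-yl and 4-methylpiperazin-1-yl, which gave values that could be read as numbers and lay within the scatter of each other, whereas ethoxy, the one group here with no ring, gave no number at all.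

The compounds shown leave open how far past the limit compound 3 lies, and so whether the change on this carbon matters at all in this cell assay. They also leave open whether a plain hydrogen, a small amine or a longer alkoxy chain at this place would give a value that can be read as a number.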